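Chloro for Fluoro on a Phenyl Already at the Limit

A few compounds are considered here, and "the series" means these few. Any claim that something is new, unique, unknown or untested is made for them only; others in the source may bear on it.

Three compounds have been measured in a functional assay on NCI-H460 cells (Homo sapiens) for antiproliferative activity, with a stated time of 72 h; a higher number here means a weaker inhibitor, a lower number a stronger inhibitor:
Compound 1 `Nc1ncnn2c([C@@H]3O[C@H](CO)[C@@H](O)[C@H]3O)cc(C#CC3CC3)c12` gives 80 nM.
Compound 2 `Nc1ncnn2c([C@@H]3O[C@H](CO)[C@@H](O)[C@H]3O)cc(C#Cc3cccs3)c12` gives 26600 nM.
Compound 3 `Nc1ncnn2c([C@@H]3O[C@H](CO)[C@@H](O)[C@H]3O)cc(-c3ccccc3F)c12` gives > 100000 nM, a limit of the assay rather than a number.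

Compound 3 thus stands at the weak end of the three, known only through (the limit of > 100000 nM in this assay, at which 1 of the 3 values shown sits). Compound 4 `Nc1ncnn2c([C@@H]3O[C@H](CO)[C@@H](O)[C@H]3O)cc(-c3ccccc3Cl)c12` differs from compound 3 by chloro in place of fluoro on an aromatic carbon. Among the compounds with values here, no measured step swaps one halogen for another. The steps that reach compound 3, an at least 1200-fold higher number from compound 1 to compound 3 (3.09 log units; beyond the scatter) and an at least 3.7-fold higher number from compound 2 to compound 3 (0.57 log units; beyond the scatter), are large and both end at the limit, and they concern the whole group on the core, not its halogen. The expected step of a number no higher from compound 3 to compound 4 (the limit leaves the size open) is therefore none beyond the scatter. Compound 4 is estimated at 100000 nM, within 30000 nM to 300000 nM, and most likely reported again only as a limit.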

Compound 4, half-maximal inhibitory concentration: > 100000 nM
Compound 4 gave a limit, no number; the forecaster's own chance of this, stated with the estimate: 80%; the middle value lies on the limit itself.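

The step from compound 3 to compound 4, chloro in place of fluoro, cannot be read, as both values are limits. The 2-chlorophenyl group still falls well short of both ethynyl groups at this position, with an at least 1200-fold higher number from compound 1 to compound 4 (3.09 log units; beyond the scatter) and an at least 3.7-fold higher number from compound 2 to compound 4 (0.57 log units; beyond the scatter). The two halogen-bearing phenyl compounds now rest at the same end of the range: the limit of > 100000 nM in this assay, at which 2 of the 4 values shown sit.

Still open, on these data alone, is whether any phenyl group here can give a measurable value. A plain phenyl, or a phenyl carrying an amine in place of the halogen, could test that.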